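Chloro to cyano on the aryl ring of a diazepine core

The compounds below may be only part of what the source reports. "The series", "measured", "known", "first", "only" and "open" are said of these compounds alone.

Measured compounds:
compound 1 `CC(C)n1nc2c(c1-c1ccccc1)CCNCC2`: 530 nM
compound 2 `c1ccc(-c2c3c(nn2C2CCC2)CCNCC3)cc1`: 500 nM
compound 3 `CC(C)n1nc2c(c1-c1ccc(Cl)cc1)CCNCC2`: 20 nM

In an ADME assay on membranes from Cortex for displacement of a labelled ligand from Adrenergic receptor alpha-1 (Rattus norvegicus), read by radioligand binding, with a stated time of 60 min (on this read-out lower numbers stand for stronger inhibition and higher numbers for weaker inhibition), compound 3 gives the lowest number of the three, beyond the scatter from both compound 2 and compound 1. Compound 4 `CC(C)n1nc2c(c1-c1ccc(C#N)cc1)CCNCC2` differs from it by cyano in place of chloro on an aromatic carbon. Of the measured steps, only a 27-fold lower number from compound 1 to compound 3 (1.42 log units; beyond the scatter) touches the same position, where it shows that a small group in place of hydrogen on that carbon brings a large gain; a 1.1-fold lower number from compound 1 to compound 2 (0.03 log units; within the scatter) concerns a different site and is within the scatter. Going by the values given here, no step tells how cyano compares with chloro here, so compound 4 is expected to hold much of that gain, with a modest rise in number, estimated as a 2.5-fold higher number from compound 3 to compound 4 (0.40 log units; beyond the scatter). Compound 4 is therefore estimated at 50 nM, between 15 nM and 170 nM.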

Compound 4, inhibition constant: 240 nM
For compound 4 the middle estimate is 4.8-fold (0.68 log units) below the measured one; measured number outside the range, above it.
By their numbers in this assay, from the lowest: compound 3; then compound 4; then compounds 2 and 1 (each within the scatter of the next).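

In this assay, the gain at this aromatic carbon turns out to depend strongly on the group placed there: a 12-fold higher number from compound 3 to compound 4 (1.08 log units; beyond the scatter) gives back most of what chloro had brought. Cyano still keeps a modest edge over hydrogen, with a 2.2-fold lower number from compound 1 to compound 4 (0.34 log units; beyond the scatter). Nothing available explains this difference between chloro and cyano.

The compounds shown leave open whether another group on this carbon, such as fluoro, methoxy or an amine, would match chloro. They also leave open whether the gain from chloro holds with cyclobutyl on the aromatic nitrogen.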